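The source may hold more compounds than are shown below. What is called first, only, known or untested is meant among the compounds shown, and "the series" means these compounds.

The three measured compounds and their values:

Compound 1, `O=c1c(C2N=C(c3ccccc3)SS2)coc2cc(Cl)ccc12`, gives 91%.
Compound 2, `O=c1c(C(=S)Nc2ccccc2)coc2ccccc12`, gives 58%.
Compound 3, `O=c1c(C(=S)Nc2ccccc2)coc2ccc(F)cc12`, gives 49%.

All three were tested in a functional assay on OVCAR-3 cells (Homo sapiens) for inhibition, read by sulforhodamine B assay, with a stated time of 48 h, tested at 100 uM; on this read-out lower numbers stand for less inhibition of growth and higher numbers for more inhibition of growth at the one concentration tested. Compound 1 stands highest of the three, and its gap to compound 2 is beyond the usual scatter of this kind of measurement; compound 1 and compound 2 differ in more than one place, and the difference between the two cores is not broken down here.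

Compounds 2 and 3 differ in one place only: fluoro in place of hydrogen on an aromatic carbon. This change gave a number 9 percentage points lower from compound 2 to compound 3 (within the scatter), so on this read-out it made no difference that can be told from noise.

Compound 4, `O=c1c(C2N=C(c3ccccc3)SS2)coc2cc(Cl)c(F)cc12`, has not yet been measured. It differs from compound 1 in one place: fluoro in place of hydrogen on an aromatic carbon. For the measured compounds named here, this is the same kind of change as the one from compound 2 to compound 3, but not the same, since in compound 4 the entering fluoro group sits ortho to a chloro group, which has no counterpart in compound 3.

Because the same kind of change gave a number 9 percentage points lower from compound 2 to compound 3 (within the scatter), compound 4 is expected to stay close to compound 1, with an estimated step of a number 3 percentage points lower from compound 1 to compound 4 (within the scatter). The expected value for compound 4 in this assay is 88%, most likely between 76% and 97%.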

Compound 4, percent growth inhibition at one concentration: 75%
Estimate against measurement, compound 4: 13 percentage points above; the measured number lies below the stated range.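

In this assay, fluoro in place of hydrogen on an aromatic carbon of the core of compound 1 gave a number 16 percentage points lower from compound 1 to compound 4 (beyond the scatter). Read on its own, this step looks different from the earlier one on the other core, yet the two cannot be told apart, so both cores fit a single picture in which this change leaves the number the same or lowers it somewhat: the same change on two cores in this assay, a number 9 percentage points lower (within the scatter) from compound 2 to compound 3 and a number 16 percentage points lower (beyond the scatter) from compound 1 to compound 4, 7 percentage points apart, within the scatter of two such steps This does not show that the change has one fixed size across the series: there are only two steps, each read at one concentration, and in compound 4 the fluoro sits ortho to a chloro group while compound 3 has no such neighbour, so these data cannot say whether that chloro group plays any part in the step.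

The compounds shown leave open what other groups would do in the place taken by fluoro, for example a methoxy group, an amine or a carboxylic acid, on either core. They also leave open whether fluoro would give a similar step on the core of compound 1 without the chloro group.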